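A few compounds are considered here, and "the series" means these few. Any claim that something is new, unique, unknown or untested is made for them only; others in the source may bear on it.

In a functional assay on HL-60 cells (Homo sapiens) for cytotoxicity, read by luminescence and CellTiter-Glo, with a stated time of 3 days (a higher number here means a weaker inhibitor, a lower number a stronger inhibitor), three compounds have been measured so far:

Compound 1 `N#Cc1ccc(NC(=O)c2ccc3cccnc3c2O)c(F)c1`: 730 nM
Compound 2 `Cc1cc(C#N)ccc1NC(=O)c1ccc2cccnc2c1O`: 710 nM
Compound 3 `N#Cc1ccc(NC(=O)c2ccc3cccnc3c2O)c(C#N)c1`: 890 nM

The three values cannot be told apart. Compound 3 stands level with the other two, as shown by a 1.2-fold higher number from compound 1 to compound 3 (0.09 log units; within the scatter) and a 1.3-fold higher number from compound 2 to compound 3 (0.10 log units; within the scatter). The remaining measured pair gives a 1.0-fold lower number from compound 1 to compound 2 (0.01 log units; within the scatter).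

The next compound, compound 4 `N#Cc1ccc(NC(=O)c2ccc3cccnc3c2O)c(Cl)c1`, has chloro in place of cyano on an aromatic carbon, ortho to a large group and meta to a cyano group: chloro in place of cyano on an aromatic carbon. All three measured steps bear on this change, since each exchanges one group for another among fluoro, methyl and cyano on an aromatic carbon. Chloro itself has not yet been measured in this series, so the comparison is indirect. With all three steps inside the scatter, no step beyond the scatter is expected in this assay, and neither direction is favoured.

The estimated step is a 1.2-fold lower number from compound 3 to compound 4 (0.06 log units; within the scatter). For compound 4 the expected value is 770 nM, with an estimated range from 400 nM to 1500 nM.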

Compound 4, half-maximal inhibitory concentration: 910 nM
Estimate against measurement, compound 4: 1.2-fold (0.07 log units) below; the measured number falls inside the stated range.
By their numbers in this assay, from the lowest: compounds 2, 1, 3 and 4 (each within the scatter of the next).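

In this assay chloro, on the aromatic carbon ortho to a large group and meta to a cyano group, does not separate from any of the three groups already seen there: the steps are a 1.0-fold higher number from compound 3 to compound 4 (0.01 log units; within the scatter) against cyano, a 1.3-fold higher number from compound 2 to compound 4 (0.11 log units; within the scatter) against methyl and a 1.2-fold higher number from compound 1 to compound 4 (0.10 log units; within the scatter) against fluoro. The exchange of cyano for chloro takes away a triple bond and a hydrogen-bond acceptor and replaces 2 heavy atoms with 1, yet no difference can be read from it, so across all four compounds the level holds and none goes against it. Nothing measured here explains why these four groups cannot be told apart.

On these data alone, what an amine, a carboxylic acid or a longer alkyl chain would do at this same position remains open, as does whether the level holds beyond these four groups. All four compounds also share the cyano group and the core, so what either contributes to the numbers in this assay cannot be judged from them.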